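Swapping the aryl amide in a pyridine N-oxide piperidine series

The source may hold more compounds than are shown below. What is called first, only, known or untested is meant among the compounds shown, and "the series" means these compounds.

Of the compounds shown here, three built on one shared core have been measured in a functional assay on HEK293 cells for agonist activity at D(4) dopamine receptor (Homo sapiens), read by FLIPR; a lower number here means a smaller maximal response, a higher number a larger maximal response. Compound 1 `O=C(NCN1CCC(c2cccc[n+]2[O-])CC1)c1cnccc1Cl` gives 44%, the lowest of the three numbers. Compound 2 `O=C(CN1CCC(c2cccc[n+]2[O-])CC1)NC1CCCCC1` gives 58%, a number beyond the scatter above that of compound 1. Compound 3 `Cc1ccc([N+](=O)[O-])cc1NC(=O)CN1CCC(c2cccc[n+]2[O-])CC1` gives 76%, the highest of the three and likewise beyond the scatter above compound 1. No two of the measured compounds differ in only one place, so these values can only be set side by side, not read as single steps.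

Compound 4 `Cc1ccc(C(=O)NCN2CCC(c3cccc[n+]3[O-])CC2)cc1C` has not yet been measured in this assay. It differs from compound 1 in one place: 3,4-dimethylphenyl in place of 4-chloropyridin-3-yl on a carbonyl carbon. Within the data shown here, the compounds measured so far give no direct guide to this exchange of one aromatic ring for another on the carbonyl carbon. Since compound 1 sits at the bottom of the range and the other aryl amide, compound 3, gives 76%, a modest upward step is expected from compound 1 to compound 4, a number 14 percentage points higher from compound 1 to compound 4 (beyond the scatter). For compound 4 the estimate is 58%, with a range from 42% to 74%.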

Compound 4, largest response reached (reported as efficacy), in percent of the reference or control that the assay uses: 65%
Estimate against measurement, compound 4: 7 percentage points below; measured number inside the range.
By their numbers in this assay, from the lowest: compound 1; then compounds 2 and 4 (each within the scatter of the next); then compound 3.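

In this assay, this is the first change in one place among the compounds shown: 3,4-dimethylphenyl in place of 4-chloropyridin-3-yl on a carbonyl carbon gives a number 21 percentage points higher from compound 1 to compound 4 (beyond the scatter). The maximal response therefore depends on which aromatic ring sits at this position, and a ring of carbon only, with no hydrogen-bond acceptor, gives the larger response of this pair. There is no evidence here to explain this step.

Going by these compounds, this single exchange alters the ring nitrogen, the chlorine and the two methyl groups together, so the share of each in the step remains open. Also open, on these data alone, is how the response would change with a plain phenyl ring or a single methyl group on that ring at this same position.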